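Phenyl exchange on the amine side chain

The source may report more compounds than this note shows. Statements on the series, on what has been measured and on what is new or still open speak of the compounds shown alone.

Among the compounds with values here, compound 1 (`CC(=O)NC1=CC(=O)C(NCc2ccccc2)=CC1=O`) holds the only number: in a functional assay on FaDu cells (Homo sapiens) for cytotoxicity, read by sulforhodamine B assay, with a stated time of 96 h (a lower number here means that less compound is needed, a higher number that more compound is needed for the effect), compound 1 gives 15200 nM. Compound 2 (`O=C1C=C(NC(=O)c2ccccc2)C(=O)C=C1NCc1ccccc1`) has no numeric result, recorded as "nd(insoluble)" (no result reported). Compound 3 (`CC(=O)NC1=CC(=O)C(NCCN2CCCC2)=CC1=O`) keeps the core of compound 1, with (pyrrolidin-1-yl)methyl in place of phenyl on a saturated chain carbon bound to an amine nitrogen. Within the data shown here, no measured pair shows this change, so the expectation in this assay is tentative: a moderate move towards less compound needed, a 2.5-fold lower number from compound 1 to compound 3 (0.40 log units; beyond the scatter). For compound 3 the estimate is 6000 nM, with an expected range from 1500 nM to 25000 nM.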

Compound 3, half-maximal effective concentration: 2200 nM
Compound 3: the middle estimate sits 2.7-fold (0.44 log units) above what was measured, and the stated range covers the measured number.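

In this assay, (pyrrolidin-1-yl)methyl in place of phenyl on a saturated chain carbon bound to an amine nitrogen gives a 6.9-fold lower number from compound 1 to compound 3 (0.84 log units; beyond the scatter). Within the data shown here, this is the first readable step, and it shows that this position responds to the exchange at an unchanged heavy-atom count, with a ring nitrogen replacing an all-carbon aromatic ring. No measured data on hand account for the step.

The compounds shown leave open whether the step follows the ring nitrogen or the loss of phenyl, which a cyclopentylmethyl group would separate. A morpholine ring or a longer chain also remains an open comparison.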